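The compounds below may be only part of what the source reports. "The series", "measured", "known", "first", "only" and "open" are said of these compounds alone.

The measured compounds:

Compound 1, `COc1cc(-c2nc3cc(F)ccc3[nH]2)ccc1OC(C)=O`: 1680 nM
Compound 2, `COc1cc(Br)c(-c2nc3cc(F)ccc3[nH]2)cc1OC`: 1570 nM
Compound 3, `COc1cc(-c2nc3cc(Cl)ccc3[nH]2)ccc1OC(C)=O`: 1680 nM

All three were tested in an assay for inhibition of Alpha amylase (Homo sapiens), with a stated time of 10 min; on this read-out lower numbers stand for stronger inhibition and higher numbers for weaker inhibition. In this assay compound 1 gives 1680 nM and compound 3 gives 1680 nM. The two differ by one change, (chloro in place of fluoro on an aromatic carbon), and the step is no change at the digits printed from compound 1 to compound 3 (within the scatter). Compound 2 gives 1570 nM in this assay; its difference from compound 1 is not broken down here, and all three values lie within the scatter of one another, so no order among them can be read off.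

Compound 4, `COc1cc(Br)c(-c2nc3cc(Cl)ccc3[nH]2)cc1OC`, has not yet been measured in this assay. It stands to compound 2 as compound 3 stands to compound 1: the change is chloro in place of fluoro on an aromatic carbon, the same change as before, made on the core of compound 2 instead of the core of compound 1. Because the measured step of no change at the digits printed from compound 1 to compound 3 (within the scatter) showed no movement, the same change on the second core is expected to give a step of no change at the digits printed from compound 2 to compound 4 (within the scatter) from compound 2 to compound 4. On that basis compound 4 is expected to give about 1570 nM in this assay, most likely between 800 nM and 3100 nM.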

Compound 4, half-maximal inhibitory concentration: 1730 nM
The estimate for compound 4 lay 1.1-fold (0.04 log units) below the measured number; low and high end bracket the measured number.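

In this assay, the second instance of chloro in place of fluoro on an aromatic carbon gives a 1.1-fold higher number from compound 2 to compound 4 (0.04 log units; within the scatter). Set beside the earlier step, the same swap reads alike on the two cores: the same change on two cores in this assay, no change at the digits printed (within the scatter) from compound 1 to compound 3 and a 1.1-fold higher number (0.04 log units; within the scatter) from compound 2 to compound 4, 1.1-fold (0.04 log units) apart, within the scatter of two such steps. This shows that, on both cores tested here, the swap leaves the read-out within the scatter, but it does not show that a larger effect would carry over, as neither step is beyond the scatter, and it says nothing about any core outside these four compounds.

The compounds shown carry only fluoro or chloro at this place, which leaves open whether an amine, a nitrile or a carboxylic acid there would give a step beyond the scatter, and whether such a step would then read alike on both cores. Going by these compounds, the two cores themselves differ in more than one place, so what each of those differences contributes on its own, including the acetate ester of compound 1 and the bromo group of compound 2, also remains open.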